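A few compounds are considered here, and "the series" means these few. Any claim that something is new, unique, unknown or untested is made for them only; others in the source may bear on it.

Compound 1 `C/C=C/C(=O)N(Cc1cc(OC)c(OC)c(OC)c1)c1ccc(OC)c(O)c1`: 6150 nM
Compound 2 `COc1ccc(CNc2cc(OC)c(OC)c(OC)c2)cc1Br`: 29400 nM
Compound 3 `COc1ccc(CN(C(C)=O)c2cc(OC)c(OC)c(OC)c2)cc1O`: 79 nM

Of the compounds shown here, three sharing a related core have been tested in a functional assay on MGC-803 cells (Homo sapiens) for inhibition, read by MTT assay, with a stated time of 48 h; a lower number here means a stronger inhibitor, a higher number a weaker inhibitor. Compound 3 gives the lowest number of the three, 79 nM. Its nearest neighbour, compound 1, gives 6150 nM, a gap that lies beyond the usual scatter, and compound 2 is furthest away with 29400 nM. Compound 3 is therefore the strongest inhibitor among the measured compounds.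

Compound 4 `COc1ccc(CN(C(=O)C(C)Br)c2cc(OC)c(OC)c(OC)c2)cc1O` has not yet been measured in this assay. It differs from compound 3 in one place:

1-bromoethyl in place of methyl on a carbonyl carbon

Among the compounds with values here, no pair of measured compounds differs by a change of this kind, so no measured step can guide the expectation directly. The replacement is a small enlargement at the amide carbonyl and leaves the rest of compound 3 untouched. The step from compound 3 to compound 4 is expected to be modest, a 1.9-fold higher number from compound 3 to compound 4 (0.28 log units; within the scatter), possibly within the scatter, with a slight lean toward a weaker inhibitor. Compound 4 is estimated at 150 nM, within a range of 30 nM to 700 nM.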

Compound 4, half-maximal inhibitory concentration: 120 nM
Compound 4: middle estimate off by 1.3-fold (0.10 log units), on the high side; low and high end bracket the measured number.
By their numbers in this assay, from the lowest: compounds 3 and 4 (each within the scatter of the next); then compound 1; then compound 2.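

In this assay, the carbonyl carbon of the amide can carry a larger group without a step beyond the usual scatter: 1-bromoethyl, with 3 heavy atoms, stands in place of methyl, with 1 heavy atom, giving a 1.5-fold higher number from compound 3 to compound 4 (0.18 log units; within the scatter). Within the data shown here, this is the first pair here that differs in this one place, so it gives the first direct reading of this position, and the pair cannot be put in order of strength. No measurement shown bears on the reason for this result.

On these data alone, what a plain ethyl group on this carbonyl carbon would give, with the added carbon but no bromine, stays open. So does whether a much longer chain, an amine or a carboxylic acid would fit the same pattern here.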